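Triazole ester series: aryl swap on the triazole nitrogen

The compounds below may be only part of what the source reports. "The series", "measured", "known", "first", "only" and "open" are said of these compounds alone.

Measured so far:
compound 1, `C/C(=C\CC/C(C)=C/CC[C@@H]1[C@@]2(C)CCC(=O)C(C)(C)[C@H]2CC[C@@]1(C)O)CC/C=C(\C)C(=O)OCc1cn(-c2ccc(C(F)(F)F)cc2)nn1`: > 150000 nM
compound 2, `C/C(=C\CC/C(C)=C/CC[C@@H]1[C@@]2(C)CCC(=O)C(C)(C)[C@H]2CC[C@@]1(C)O)CC/C=C(\C)C(=O)OCc1cn(C[C@@H]2O[C@H](n3ccc(=O)[nH]c3=O)[C@H]3OC(C)(C)O[C@H]32)nn1`: > 150000 nM

In a functional assay on MDA-MB-231 cells (Homo sapiens) for antiproliferative activity, read by MTT assay, with a stated time of 48 h (on this read-out lower numbers stand for stronger inhibition and higher numbers for weaker inhibition), compound 1 gives only a limit, > 150000 nM. Compound 2 likewise gives only a limit, > 150000 nM. Both results sit at the limit of > 150000 nM in this assay, at which 2 of the 2 values shown sit, so compound 1 stands at the assay limit alongside compound 2, with no ordering between them. Compound 3 is `C/C(=C\CC/C(C)=C/CC[C@@H]1[C@@]2(C)CCC(=O)C(C)(C)[C@H]2CC[C@@]1(C)O)CC/C=C(\C)C(=O)OCc1cn(-c2cccc(Cl)c2)nn1`; it differs from compound 1 by 3-chlorophenyl in place of 4-(trifluoromethyl)phenyl on an aromatic nitrogen. Within the data shown here, no measured step between compounds is available, so there is no basis to expect anything beyond the scatter. The expected step of a number no higher from compound 1 to compound 3 (the limit leaves the size open) is therefore none beyond the scatter. Compound 3 is estimated at 150000 nM, with a range from 30000 nM to 300000 nM, and most likely reported again as a limit.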

Compound 3, half-maximal inhibitory concentration: 103000 nM
Estimate against measurement, compound 3: 1.5-fold (0.16 log units) above, and the stated range covers the measured number.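

In this assay compound 3 is the only compound shown that gives a number rather than a limit, 103000 nM. Placing 3-chlorophenyl in place of 4-(trifluoromethyl)phenyl on the aromatic nitrogen gives an at least 1.4-fold lower number from compound 1 to compound 3 (0.16 log units; that floor lies within the scatter), a step that starts from a limit and so fixes only a floor. The other compounds shown remain at the limit: the limit of > 150000 nM in this assay, at which 2 of the 3 values shown sit.

This single pair cannot separate the effect of the chlorine from that of its ring position. From the compounds shown here alone, how a plain phenyl, or an aryl group bearing an amine or a carboxylic acid, would read at this nitrogen stays open.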